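The compounds below may be only part of what the source reports. "The series", "measured", "known", "first", "only" and "open" are said of these compounds alone.

Measured in an ADME assay on microsomes from liver (Homo sapiens) for metabolic stability, read by HPLC, with a stated time of 10 min, tested at 3 uM; a higher number here means that more of the compound is left, a lower number that less of the compound is left:
- compound 1 `CC[C@H](C1CC1)n1cc(Cl)nc(Nc2cc(C)c(OC)nc2C)c1=O`: 51%
- compound 2 `COc1nc(C)c(Nc2nc(Cl)cn([C@H](C)C3CC3)c2=O)cc1C`: 77%
- compound 3 `CC[C@H](C1CC1)n1cc(C#N)nc(Nc2cc(C)c(OC)nc2C)c1=O`: 81%

Compound 3 and compound 2 lie within the scatter of each other, and both stand clear of compound 1. Compound 4 `COc1nc(C)c(Nc2nc(C#N)cn([C@H](C)C3CC3)c2=O)cc1C` differs from compound 3 as follows: hydrogen in place of methyl on a saturated chain carbon, two bonds along the chain from an aromatic nitrogen and a saturated ring carbon. The same change, made with chloro in place of cyano, gave a number 26 percentage points higher from compound 1 to compound 2 (beyond the scatter). The swap to cyano gave a number 30 percentage points higher from compound 1 to compound 3 (beyond the scatter). Compound 4 carries both changes, so a rise is expected, but a smaller one, since compound 3 at 81% leaves limited room on this read-out. The expected step is a number 9 percentage points higher from compound 3 to compound 4 (within the scatter). For compound 4 the estimated value is 90%, with an expected range of 79% to 98%.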

Compound 4, percent of the compound remaining: 99%
Beside the measured number, compound 4's estimate is 9 percentage points below it; measured number outside the range, above it.
By their numbers in this assay, from the lowest: compound 1; then compounds 2 and 3 (each within the scatter of the next); then compound 4.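

In this assay, the change from 1-cyclopropylpropyl to 1-cyclopropylethyl still helps where cyano already stands, with a number 18 percentage points higher from compound 3 to compound 4 (beyond the scatter): the same change on two cores in this assay, a number 26 percentage points higher (beyond the scatter) from compound 1 to compound 2 and a number 18 percentage points higher (beyond the scatter) from compound 3 to compound 4, 8 percentage points apart, within the scatter of two such steps. The swap from chloro to cyano likewise holds on the 1-cyclopropylethyl side, with a number 22 percentage points higher from compound 2 to compound 4 (beyond the scatter): the same change on two cores in this assay, a number 30 percentage points higher (beyond the scatter) from compound 1 to compound 3 and a number 22 percentage points higher (beyond the scatter) from compound 2 to compound 4, 8 percentage points apart, within the scatter of two such steps. Both changes point the same way on both cores, and none of the four compounds goes against this.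

Compound 4, at 99%, sits so near the top of this read-out that any further gain could hardly show. Open, from the compounds shown here alone, is whether a cyclobutyl in place of the cyclopropyl, or a carboxamide in place of the cyano, would keep this much compound remaining.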